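This account rests on a few compounds, and the source may have more. Where it says the series, first, only, none or still open, it means among the compounds named here.

For the measured compounds named here, in a functional assay on K562 cells (Homo sapiens) for cytotoxicity, read by fluorescence, with a stated time of 72 h (a higher number here means a weaker inhibitor, a lower number a stronger inhibitor), compound 1 `CC(C)c1n[nH]c2c(NCc3ccc(-c4ccccn4)cc3)nc(NCCO)nc12` gives 38 nM and compound 2 `CC(C)c1n[nH]c2c(NCc3ccc(-c4ccccn4)cc3)nc(NCC(N)CO)nc12` gives 700 nM, the higher of the two numbers so far. Next comes compound 3 `CC(C)c1n[nH]c2c(NCc3ccc(-c4ccccn4)cc3)nc(NCc3ccc(-c4ccccn4)cc3)nc12`, which carries this change: 4-(pyridin-2-yl)phenyl in place of 1-amino-2-hydroxyethyl on a saturated chain carbon bound to a nitrogen on an aromatic ring. Going by the values given here, only one measured step bears on it: an 18-fold higher number from compound 1 to compound 2 (1.27 log units; beyond the scatter). That step is large and beyond the scatter, and it too is a change on a saturated chain carbon bound to a nitrogen on an aromatic ring. It shows that the number can move strongly with the group at this place, but it does not show a direction for 4-(pyridin-2-yl)phenyl. Among the compounds with values here, no measured compound carries a ring there, so the expectation stays broad. The expected change is a 1.3-fold higher number from compound 2 to compound 3 (0.11 log units; within the scatter), which means no step beyond the scatter is expected. For compound 3 the estimated value in this assay is 900 nM, with an expected range of 200 nM to 4000 nM.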

Compound 3, half-maximal inhibitory concentration: 2540 nM
Compound 3: the middle estimate sits 2.8-fold (0.45 log units) below what was measured; measured number inside the range.
By their numbers in this assay, from the lowest: compound 1; then compound 2; then compound 3.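

In this assay, placing 4-(pyridin-2-yl)phenyl on a saturated chain carbon bound to a nitrogen on an aromatic ring gives a 3.6-fold higher number from compound 2 to compound 3 (0.56 log units; beyond the scatter) and, against hydroxymethyl, a 67-fold higher number from compound 1 to compound 3 (1.83 log units; beyond the scatter). Among these three compounds, the group with two aromatic rings therefore goes with the highest number, above both open-chain groups, so the direction seen with 1-amino-2-hydroxyethyl continues with a very different group. No evidence on the cause of either step is at hand.

Open, on these data alone, is whether the rise follows the two aromatic rings or the loss of the hydroxyl group. A single phenyl ring, a longer chain ending in a hydroxyl group, or an aminomethyl group at this place would help separate these features.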